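Thiophen-2-yl to Furan-2-yl on One Shared Core

The source may hold more compounds than are shown below. What is called first, only, known or untested is meant among the compounds shown, and "the series" means these compounds.

Compound 1 `CN1C[C@@H](c2ccccc2)[C@@]2(Cc3ccccc3C2=O)[C@@]12C(=O)Nc1ccccc12`, compound 2 `CN1C[C@@H](c2ccc(F)cc2)[C@@]2(Cc3ccccc3C2=O)[C@@]12C(=O)Nc1ccccc12` and compound 3 `CN1C[C@@H](c2cccs2)[C@@]2(Cc3ccccc3C2=O)[C@@]12C(=O)Nc1ccccc12` share one core and differ only in the group on a saturated ring carbon. In a functional assay on the whole organism (strain Wister albino) for inhibition, with Rattus norvegicus as the target, read by paw edema, with a stated time of 1 h, at a dose of 50 mg/kg by the intraperitoneal route (on this read-out higher numbers stand for more inhibition at the one dose given (going by the name of the read-out) and lower numbers for less inhibition), compound 1 gives 56%, compound 2 gives 40.6% and compound 3 gives 49.9%. Among the measured compounds shown here, the one change that clearly registered was a number 15.4 percentage points lower from compound 1 to compound 2 (beyond the scatter). Compound 3 cannot be told apart from either neighbour, since a number 6.1 percentage points lower from compound 1 to compound 3 (within the scatter) and a number 9.3 percentage points higher from compound 2 to compound 3 (within the scatter) both stay within the usual scatter.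

Compound 4 `CN1C[C@@H](c2ccco2)[C@@]2(Cc3ccccc3C2=O)[C@@]12C(=O)Nc1ccccc12` differs from compound 3 in one place: furan-2-yl in place of thiophen-2-yl on a saturated ring carbon. For the measured compounds named here, no measured step swaps these two five-membered aromatic rings for each other, so only the steps that end in compound 3 bear on the question, and both stayed small. Because a number 6.1 percentage points lower from compound 1 to compound 3 (within the scatter) and a number 9.3 percentage points higher from compound 2 to compound 3 (within the scatter) lay within the scatter, a shift of this kind is expected to be small as well: a number 1.9 percentage points lower from compound 3 to compound 4 (within the scatter). For compound 4 the estimate in this assay is 48%, with a likely range from 35% to 61%.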

Compound 4, a percentage reported as inhibition, in the whole organism at one dose (the size of the read-out at that dose, not a potency): 48.8%
Beside the measured number, compound 4's estimate is 0.8 percentage points below it, within the range that was stated.
By their numbers in this assay, from the lowest: compounds 2, 4, 3 and 1 (each within the scatter of the next, the first and the last beyond it).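

Among the compounds shown here, the exchange of thiophen-2-yl for furan-2-yl puts oxygen where sulfur stood in a five-membered aromatic ring, and it is the first direct swap of one such ring for another on this saturated ring carbon; in this assay it gives a number 1.1 percentage points lower from compound 3 to compound 4 (within the scatter), so the two rings cannot be told apart here. Furan-2-yl also stays close to both six-membered groups, with a number 8.2 percentage points higher from compound 2 to compound 4 (within the scatter) and a number 7.2 percentage points lower from compound 1 to compound 4 (within the scatter), so compound 4 cannot be separated from any of the three earlier compounds. Nothing measured here explains these numbers.

On these data alone, what an amine, a carboxylic acid or a longer chain would do on this carbon remains open. Also open, as far as these compounds go, is whether compound 3 and compound 4 would stay this close at other doses or times.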